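Cytotoxicity limits across a chloro-to-methyl pair

The source may hold more compounds than are shown below. What is called first, only, known or untested is meant among the compounds shown, and "the series" means these compounds.

The series is followed in an ADME assay on Huh-7 cells (Homo sapiens) for cytotoxicity, read by a luciferase reporter and WST assay, with a stated time of 3 days; a lower number here means that less compound is tolerated, a higher number that more compound is tolerated. Compound 1 `O=C(Nc1ccc(Cl)cc1)c1c(NO)cc(-c2ccccc2)oc1=O` reaches only the limit of the assay, giving > 20000 nM. Compound 2 `Cc1ccc(NC(=O)c2c(NO)cc(-c3ccccc3)oc2=O)cc1` likewise stops at the assay limit, with > 20000 nM. The change between them is methyl in place of chloro on an aromatic carbon, and the step that the two limits leave unreadable from compound 1 to compound 2 cannot be sized because both ends sit at the limit of > 20000 nM in this assay, at which 3 of the 3 values shown sit. Compound 3 `CNC(=O)c1c(NO)cc(-c2ccc(Cl)cc2)oc1=O` also returns a limit, > 20000 nM. The difference between the core of compound 3 and the core of compound 1 is not broken down here.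

Compound 4 `CNC(=O)c1c(NO)cc(-c2ccc(C)cc2)oc1=O` has not yet been measured. Relative to compound 3 it carries methyl in place of chloro on an aromatic carbon, the same change as that from compound 1 to compound 2, made at the same kind of position. All three measured compounds sit at the limit, so no read of this change on this assay exists yet. Compound 4 is expected to stay at or beyond the limit as well, a step that the limit leaves unreadable from compound 3 to compound 4, because compound 3 and the earlier pair all rest on (the limit of > 20000 nM in this assay, at which 3 of the 3 values shown sit). The estimate for compound 4 in this assay is therefore 25000 nM, with a range of 12000 nM to 60000 nM.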

Compound 4, half-maximal cytotoxic concentration: > 20000 nM
Compound 4: a limit, no number; the forecaster's own chance of this, stated with the estimate: 85%; the middle value is on the limit's open side.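

No step can be read from compound 3 to compound 4 in this assay, and the same holds for the methyl-for-chloro change in this pair, since both ends are limits and not numbers: the limit of > 20000 nM in this assay, at which 4 of the 4 values shown sit.
The compounds shown leave open where the half-maximal cytotoxic concentration of any of them lies, and whether methyl and chloro differ at all on this read-out.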